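Aminothiophene ketones: furanyl to difluorophenyl exchange

A few compounds are considered here, and "the series" means these few. Any claim that something is new, unique, unknown or untested is made for them only; others in the source may bear on it.

Of the compounds shown here, three have been measured, and none shows appreciable displacement. In an assay on CHO cells for displacement of a labelled ligand from adenosine receptor A3 (Homo sapiens), read by scintillation counting, tested at 10 uM (a higher number here means more inhibition at the concentration tested (going by the name of the read-out), a lower number less inhibition), compound 1 `Cc1csc(N)c1C(=O)c1ccc(Cl)cc1` gives 1%. Compound 2 `CC(C)Cc1csc(N)c1C(=O)c1ccc(Cl)cc1` gives 1% in this assay, and no change at the digits printed from compound 1 to compound 2 (within the scatter). Compound 3 `CC(C)(C)Cc1c(-c2ccoc2)sc(N)c1C(=O)c1ccc(Cl)cc1`, which carries both a neopentyl group and a furan-3-yl group on the shared core, gives 1% in this assay, level with compound 1 and compound 2 at the digits shown.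

Compound 4 `CC(C)(C)Cc1c(-c2c(F)cccc2F)sc(N)c1C(=O)c1ccc(Cl)cc1` is not yet measured. It differs from compound 3 in one place: 2,6-difluorophenyl in place of furan-3-yl on an aromatic carbon. The group enters on an aromatic carbon of a five-membered aromatic ring with 1 sulfur, next to the ring sulfur, while the rest of the molecule, including the neopentyl group and the amino group, is unchanged.

Among the measured compounds shown here, no measured step touches this position; the only step available, from compound 1 to compound 2, concerns a saturated chain carbon and lies within the scatter. All three measured compounds sit at the same low level, so the working expectation is that compound 4 stays near that level and that the step of a number 2 percentage points higher from compound 3 to compound 4 (within the scatter) stays within the scatter. Compound 4 is therefore estimated at 3% in this assay, with a range from -6% to 15%.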

Compound 4, a percentage reported as inhibition, at one concentration (the size of the read-out at that concentration, not a potency): 1%
For compound 4 the middle estimate is 2 percentage points above the measured one; low and high end bracket the measured number.
By their numbers in this assay, from the lowest: compounds 1, 2, 3 and 4 (each within the scatter of the next).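

In this assay, the aromatic carbon next to the ring sulfur now has a step of its own: 2,6-difluorophenyl in place of furan-3-yl gives no change at the digits printed from compound 3 to compound 4 (within the scatter). The earlier compounds shown here offered no step at this position, and this one shows that the read-out stays where it was when a five-membered aromatic ring with 1 hetero atom and 1 hydrogen-bond acceptor gives way to a larger six-membered aromatic ring of carbon only, with 0 hydrogen-bond acceptors. Nothing available bears on why this exchange leaves the read-out as it is.

Since both compounds of the step lie at the same low level, it does not show how this position would behave in a compound with clear displacement, and a single concentration gives no potency. On these data alone, whether a basic amine such as a piperidine or a carboxylic acid on this aromatic carbon, or an amide in place of the amino group, would give a read-out beyond the scatter remains open.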